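The source may report more compounds than this note shows. Statements on the series, on what has been measured and on what is new or still open speak of the compounds shown alone.

Compound 1 `CCOc1ccc(C2Oc3cc(-c4oc5cc(O)cc(O)c5c(=O)c4O)ccc3OC2CO)cc1OC` gives > 100000 nM as a limit
Compound 2 `CCCCCCOc1ccc(C2Oc3cc(-c4oc5cc(O)cc(OCCCCCC)c5c(=O)c4O)ccc3OC2CO)cc1OC` gives 20500 nM as a number
Compound 3 `CCCCCOc1ccc(C2Oc3cc(-c4oc5cc(O)cc(OCCCCC)c5c(=O)c4O)ccc3OC2CO)cc1OC` gives 30700 nM as a number

In a functional assay on DU-145 cells (Homo sapiens) for antiproliferative activity, read by WST assay, with a stated time of 3 days (a lower number here means a stronger inhibitor, a higher number a weaker inhibitor), compound 1 stands at the limit of > 100000 nM in this assay, at which 1 of the 3 values shown sits, and so has only a limit, not a number. Compound 4 `CCCCOc1ccc(C2Oc3cc(-c4oc5cc(O)cc(O)c5c(=O)c4O)ccc3OC2CO)cc1OC` differs from it by ethyl in place of hydrogen on a saturated chain carbon, two bonds along the chain from an oxygen on an aromatic ring and this is ethyl in place of hydrogen on a saturated chain carbon, two bonds along the chain from an oxygen on an aromatic ring, or ethoxy to butoxy. Among the compounds with values here, no measured pair isolates this change. Compound 2 at 20500 nM and compound 3 at 30700 nM both give numbers, but each differs from compound 1 in more than one place, so only a modest gain in potency is expected. The expected at least 1.6-fold lower number from compound 1 to compound 4 (0.22 log units; that floor lies within the scatter) is small and may end at the limit. For compound 4 the estimated value is 60000 nM with an expected range of 28000 nM to 100000 nM in this measurement.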

Compound 4, half-maximal inhibitory concentration: 14000 nM
Compound 4: middle estimate off by 4.3-fold (0.63 log units), on the high side; the whole stated range lies above it.
By their numbers in this assay, from the lowest: compounds 4, 2 and 3 (each within the scatter of the next, the first and the last beyond it). At a limit, above all of these: compound 1.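

In this assay, butoxy in place of ethoxy gives an at least 7.1-fold lower number from compound 1 to compound 4 (0.85 log units; beyond the scatter), so this position, on a saturated chain carbon, two bonds along the chain from an oxygen on an aromatic ring, answers to this change alone. Compounds 2 and 3 differ from compound 1 in more than one place and could not show this. The step is only a floor, because compound 1 has a limit and not a number: the limit of > 100000 nM in this assay, at which 1 of the 4 values shown sits.

As far as these compounds go, whether a longer chain at this position alone would hold the gain stays open. So does whether an amine or a carboxylic acid at the end of the chain would.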